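The source may hold more compounds than are shown below. What is called first, only, known or untested is meant among the compounds shown, and "the series" means these compounds.

In a functional assay on T47D cells (Homo sapiens) for cytotoxicity, read by MTT assay, with a stated time of 48 h (on this read-out higher numbers stand for weaker inhibition and lower numbers for stronger inhibition), two compounds sharing one core have been measured so far. Compound 1 `CCc1ccc(NC(=S)N/N=C\c2ccnc3ccccc23)cc1` gives 1280 nM. Compound 2 `S=C(N/N=C\c1ccnc2ccccc12)Nc1ccc(Cl)cc1` gives 1270 nM, which places it level with compound 1, within the scatter of repeated measurements. The next compound, compound 3 `S=C(N/N=C\c1ccnc2ccccc12)Nc1ccc(Br)cc1`, differs from compound 2 in a single place: bromo in place of chloro on an aromatic carbon. Put differently, the 4-chlorophenyl of compound 2 becomes the 4-bromophenyl of compound 3. Within the data shown here, only one measured step bears on this change: a 1.0-fold lower number from compound 1 to compound 2 (0.00 log units; within the scatter), with chloro in place of ethyl on an aromatic carbon. Among the measured compounds shown here, that exchange left the number unmoved, but it is a single step, and no bromo compound has yet been measured. No step beyond the scatter is therefore expected in this assay, in either direction. The estimated step is a 1.1-fold lower number from compound 2 to compound 3 (0.02 log units; within the scatter). For compound 3, the expected value is 1200 nM, with an estimated range of 600 nM to 2500 nM.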

Compound 3, half-maximal inhibitory concentration: 1480 nM
The estimate for compound 3 lay 1.2-fold (0.09 log units) below the measured number; the range from low to high includes it.
By their numbers in this assay, from the lowest: compounds 2, 1 and 3 (each within the scatter of the next).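

In this assay, the change from chloro to bromo on the aromatic carbon para to a large group gives a 1.2-fold higher number from compound 2 to compound 3 (0.07 log units; within the scatter), so this halogen exchange does not separate the two compounds at this position. The comparison with the ethyl compound gives a 1.2-fold higher number from compound 1 to compound 3 (0.06 log units; within the scatter), which extends the earlier single comparison of ethyl and chloro to a third group: ethyl, chloro and bromo all read alike here, and none of the three can be ranked against the others. Nothing measured here offers an explanation for this level reading.

The compounds shown leave open whether a different kind of group at this same place, such as an amine, a carboxylic acid or a longer chain, would shift the number beyond the scatter. They also leave open whether ethyl, chloro and bromo would still read alike if the shared core were altered.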